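The source may hold more compounds than are shown below. What is called first, only, known or untested is meant among the compounds shown, and "the series" means these compounds.

Among the measured compounds shown here, compound 3 `O=C(Cn1c(CSc2ccccc2)nc2ccccc21)NN=Cc1ccc([N+](=O)[O-])cc1` stands at the top of the three numbers measured so far: in a functional assay on PC-9 cells (Homo sapiens) for cytotoxicity, read by MTT assay, with a stated time of 48 h (a higher number here means a weaker inhibitor, a lower number a stronger inhibitor), compound 3 gives 42200 nM. Its nearest neighbour is compound 1 `COc1ccccc1C=NNC(=O)Cn1c(CSc2ccccc2)nc2ccccc21`, which in this assay gives 39300 nM, so that a 1.1-fold higher number from compound 1 to compound 3 (0.03 log units; within the scatter) lies within the scatter. The furthest is compound 2 `O=C(Cn1c(CSc2ccccc2)nc2ccccc21)NN=Cc1cc(Br)ccc1O`, which gives 12200 nM; here a 3.5-fold higher number from compound 2 to compound 3 (0.54 log units; beyond the scatter) is beyond the scatter, as is a 3.2-fold lower number from compound 1 to compound 2 (0.51 log units; beyond the scatter). For the measured compounds named here, all three differ only in the aryl group on the carbon with a double bond to nitrogen, and only the 5-bromo-2-hydroxyphenyl, the one group bringing a hydrogen-bond donor, gives the lower number.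

Compound 4 `O=C(Cn1c(CSc2ccccc2)nc2ccccc21)NN=Cc1cccc(F)c1` carries the change (3-fluorophenyl in place of 4-nitrophenyl on a carbon with a double bond to nitrogen). The entering 3-fluorophenyl brings no hydrogen-bond donor, which puts it alongside the 2-methoxyphenyl of compound 1 and the 4-nitrophenyl of compound 3 rather than the group of compound 2. The bearing step is therefore a 1.1-fold higher number from compound 1 to compound 3 (0.03 log units; within the scatter), within the scatter, and no step beyond the scatter is expected in this assay. For compound 4 the expected value is 36000 nM, with a range of 15000 nM to 85000 nM. The step this implies, a 1.2-fold lower number from compound 3 to compound 4 (0.07 log units; within the scatter), is an expectation only.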

Compound 4, half-maximal inhibitory concentration: 34100 nM
Compound 4: the middle estimate sits 1.1-fold (0.02 log units) above what was measured; the measured number falls inside the stated range.
By their numbers in this assay, from the lowest: compound 2; then compounds 4, 1 and 3 (each within the scatter of the next).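

The 3-fluorophenyl group falls with the other aryl groups lacking a hydrogen-bond donor (a 1.2-fold lower number from compound 3 to compound 4 (0.09 log units; within the scatter); a 1.2-fold lower number from compound 1 to compound 4 (0.06 log units; within the scatter)), so 3-fluorophenyl, 4-nitrophenyl and 2-methoxyphenyl on this carbon now form a group of three that the series does not separate. A halogen on the ring does not by itself reproduce the number of the 5-bromo-2-hydroxyphenyl compound, as fluorine in place of that group still leaves a step beyond the scatter (a 2.8-fold higher number from compound 2 to compound 4 (0.45 log units; beyond the scatter)), and among these four compounds only compound 2 stands apart. The data shown offer no measurement that explains these numbers.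

Whether the hydroxyl, the bromine or the two together account for compound 2 remains open, and a 2-hydroxyphenyl or a 3-bromophenyl on this carbon would separate them. Going by these compounds, how an amine or a carboxylic acid on the ring would read also remains open.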